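A few compounds are considered here, and "the series" means these few. Any claim that something is new, unique, unknown or untested is made for them only; others in the source may bear on it.

Measured in a functional assay on QG-56 cells (Homo sapiens) for antiproliferative activity; on this read-out lower numbers stand for stronger inhibition and higher numbers for weaker inhibition:
- compound 1 `COc1ccc(C(O)(c2cc3cc([N+](=O)[O-])cc(-c4ccccc4)c3o2)c2cncn2C)cc1`: 4970 nM
- compound 2 `Cn1cncc1C(O)(c1ccc(C(=O)OC(C)(C)C)cc1)c1cc2cc([N+](=O)[O-])cc(-c3ccccc3)c2o1`: 6250 nM
- compound 3 `Cn1cncc1C(O)(c1ccc(Cl)cc1)c1cc2cc(C(=O)NN3CCOCC3)cc(-c3ccccc3)c2o1`: 73.6 nM

Compound 2 stands level with compound 1 in this assay, since a 1.3-fold higher number from compound 1 to compound 2 (0.10 log units; within the scatter) lies within the scatter. Compound 3 gives a far lower number than either, but it differs from compound 2 in more than one place and says little about a single change.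

The next compound is compound 4 `Cn1cncc1C(O)(c1ccc(C(=O)O)cc1)c1cc2cc([N+](=O)[O-])cc(-c3ccccc3)c2o1`, and the change from compound 2 is hydrogen in place of tert-butyl on an oxygen next to a carbonyl group, which turns tert-butoxycarbonyl to carboxy. For the measured compounds named here, only one measured step touches this group, namely a 1.3-fold higher number from compound 1 to compound 2 (0.10 log units; within the scatter), where tert-butoxycarbonyl took the place of methoxy on an aromatic carbon. Going by the values given here, that swap left the number within the scatter, yet no measured compound carries a carboxy group, so the evidence is indirect and the range must stay wide. The expected outcome is a 1.3-fold higher number from compound 2 to compound 4 (0.11 log units; within the scatter), an estimated step no larger than the scatter. For compound 4 the estimated value is 8000 nM, with an expected range from 2500 nM to 25000 nM.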

Compound 4, half-maximal inhibitory concentration: > 10000 nM
Compound 4: only a limit was reported; the forecaster's own chance of this, stated with the estimate: 10%; middle value at least 1.2-fold (0.09 log units) from the limit.
By their numbers in this assay, from the lowest: compound 3; then compounds 1 and 2 (each within the scatter of the next). At a limit, above all of these: compound 4.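

Compound 4 is reported only as a limit in this assay, > 10000 nM. Hydrogen in place of tert-butyl on an oxygen next to a carbonyl group, which turns tert-butoxycarbonyl to carboxy, gives an at least 1.6-fold higher number from compound 2 to compound 4 (0.20 log units; that floor lies within the scatter), and carboxy in place of methoxy on an aromatic carbon gives an at least 2.0-fold higher number from compound 1 to compound 4 (0.30 log units; that floor lies within the scatter); both floors lie within the scatter, so neither step by itself establishes a real loss. What is new is that, where compound 1 and compound 2 stood level with exact numbers, the carboxy group gives no exact number, and the true size of both steps cannot be read: the limit of > 10000 nM in this assay, at which 1 of the 4 values shown sits.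

As far as these compounds go, how a methyl ester, an amide or an amine would read on this aromatic carbon stays open. Compound 3, at 73.6 nM, differs from compound 4 in more than one place, so which change goes with its far lower number is also unresolved.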